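Swapping Isobutyl for Cyclohexyl on a Shared Core

The source may report more compounds than this note shows. Statements on the series, on what has been measured and on what is new or still open speak of the compounds shown alone.

Compound 1 `Brc1cccc(N(CC2CC2)C2=NCCN2)c1Br`: 11.1
Compound 2 `CC(C)CCN(C1=NCCN1)c1c(Br)cccc1Br`: 10.9
Compound 3 `C/C=C/CN(C1=NCCN1)c1c(Br)cccc1Br`: 11

Of the compounds shown here, three sharing the core of compound 2 have been measured in a physicochemical assay for acid dissociation. Compound 2 gives 10.9. Its nearest neighbour on the numbers is compound 3, and compound 1 lies furthest away, yet both gaps are within the scatter, so the three numbers cannot be told apart.

Compound 4 `Brc1cccc(Br)c1N(CC1CCCCC1)C1=NCCN1` has not yet been measured. It differs from compound 2 in one place: cyclohexyl in place of isobutyl on a saturated chain carbon bound to a nitrogen on an aromatic ring.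

Within the data shown here, only one measured step bears on this change, the one at the same position: a number 0.10 log units higher from compound 2 to compound 3 (within the scatter). That exchange of one chain for another on the saturated chain carbon bound to the nitrogen on the aromatic ring left the acid dissociation constant unmoved beyond the scatter. Compound 1, carrying a different group at the same place, gives 11.1, again indistinguishable from compound 2. Nothing among the three suggests that the group at this position moves the read-out, so no step beyond the scatter is expected for compound 4.

The estimated step for compound 4 is therefore a number 0.10 log units higher from compound 2 to compound 4 (within the scatter). Compound 4 is expected to give 11, within a range from 10.7 to 11.3.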

Compound 4, acid dissociation constant: 11.2
Compound 4: the middle estimate sits 0.20 log units below what was measured; low and high end bracket the measured number.
By their numbers in this assay, from the lowest: compounds 2, 3, 1 and 4 (each within the scatter of the next).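

Cyclohexyl, with its six-membered ring of carbon only, replaces an open chain on the saturated chain carbon bound to a nitrogen on an aromatic ring, and in this assay this gives a small step in each single-place comparison: a number 0.30 log units higher from compound 2 to compound 4 (within the scatter) and a number 0.20 log units higher from compound 3 to compound 4 (within the scatter). Compound 2 and compound 3 had shown only that one open chain could replace another at this place, whereas compound 4 extends that result to a larger group of 6 heavy atoms containing a ring, with both steps still within the scatter. The data shown offer no measured explanation for this outcome.

Going by these compounds, the groups compared in these single-place steps consist of carbon and hydrogen only and carry no net charge, so it remains open whether an amine or a carboxylic acid at this place would also stay within the scatter. On these data alone, it also remains open whether a phenyl group, an aromatic ring rather than the saturated cyclohexyl, or a much longer chain would leave the read-out equally unmoved.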